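Replacing 4-fluorophenoxy with (4-fluorophenyl)carbonyl in the series

A few compounds are considered here, and "the series" means these few. Any claim that something is new, unique, unknown or untested is made for them only; others in the source may bear on it.

Compound 1 (`O=C(c1ccc(F)cc1)c1cccc(/C=c2\[nH]c(=O)/c(=C/c3c[nH]cn3)[nH]c2=O)c1`) gives 4.3 nM and compound 2 (`Cc1ccc(/C=c2\[nH]c(=O)/c(=C/c3cccc(C(=O)c4ccc(F)cc4)c3)[nH]c2=O)o1`) gives 3.7 nM in a functional assay on BXPC-3 cells (Homo sapiens) for cytotoxicity, read by MTT assay, with a stated time of 72 h (a lower number here means a stronger inhibitor, a higher number a weaker inhibitor), with compound 3 (`COCc1ccc(/C=c2\[nH]c(=O)/c(=C/c3cccc(Oc4ccc(F)cc4)c3)[nH]c2=O)o1`) at 6.6 nM within the scatter of both. Compound 4 (`COCc1ccc(/C=c2\[nH]c(=O)/c(=C/c3cccc(C(=O)c4ccc(F)cc4)c3)[nH]c2=O)o1`) carries (4-fluorophenyl)carbonyl in place of 4-fluorophenoxy on an aromatic carbon. Among the measured compounds shown here, no measured pair isolates this change. For the measured compounds named here, the one measured step (a 1.2-fold lower number from compound 1 to compound 2 (0.07 log units; within the scatter)) lies elsewhere in the structure and stays within the scatter. Compound 4 shares the entering group with compound 2, and compound 2 gives 3.7 nM while differing from compound 3 by no more than the scatter. No step beyond the scatter is therefore expected in this assay (estimated step a 1.3-fold lower number from compound 3 to compound 4 (0.12 log units; within the scatter)). For compound 4 the estimated value is 5 nM (expected range 2.5 nM to 10 nM).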

Compound 4, half-maximal inhibitory concentration: 2 nM
Estimate against measurement, compound 4: 2.5-fold (0.40 log units) above; the measured number lies below the stated range.
By their numbers in this assay, from the lowest: compounds 4, 2, 1 and 3 (each within the scatter of the next, the first and the last beyond it).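

In this assay, among the compounds shown here, (4-fluorophenyl)carbonyl in place of 4-fluorophenoxy on the aromatic carbon gives the first step at this position, modest but beyond the scatter (a 3.3-fold lower number from compound 3 to compound 4 (0.52 log units; beyond the scatter)). With the carbonyl kept, methoxy on the saturated chain carbon stays within the scatter (a 1.9-fold lower number from compound 2 to compound 4 (0.27 log units; within the scatter)), while 5-(methoxymethyl)furan-2-yl in place of 1H-imidazol-4-yl gives a modest step beyond it (a 2.2-fold lower number from compound 1 to compound 4 (0.33 log units; beyond the scatter)). No evidence on hand accounts for these steps.

Open: whether the carbonyl step holds with 5-methylfuran-2-yl or 1H-imidazol-4-yl as the partner group, and how an amine or a carboxylic acid would read on this aromatic carbon.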